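A few compounds are considered here, and "the series" means these few. Any claim that something is new, unique, unknown or untested is made for them only; others in the source may bear on it.

Measured in a functional assay on MCF7 cells (Homo sapiens) for cytotoxicity, read by MTT assay, with a stated time of 72 h; on this read-out higher numbers stand for weaker inhibition and lower numbers for stronger inhibition:

Compound 1 `O=C(NCc1ccc(F)cc1)c1nc(NCCO)c2cccnc2c1O`: "not determined" (no result reported)
Compound 2 `N[C@H]1CC[C@H](Nc2c(C(=O)NCc3ccc(Oc4ccccc4)cc3)nc(Br)c3cccnc23)CC1`: 7900 nM
Compound 3 `CN(C)c1ccc(CNC(=O)c2nc(Br)c3cccnc3c2N[C@H]2CC[C@H](N)CC2)cc1`: 5000 nM

Only two of these compounds carry a number, and compound 3 has compound 2 as its sole numerical neighbour. The two lie within the scatter of each other, so neither can be ranked above the other. Compound 1 adds no number to the comparison.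

The next compound is compound 4 `N[C@H]1CC[C@H](Nc2c(C(=O)NCc3cccs3)nc(Br)c3cccnc23)CC1`, which differs from compound 3 as follows: thiophen-2-yl in place of 4-(dimethylamino)phenyl on a saturated chain carbon bound to an amide-type nitrogen. In words, thiophen-2-yl stands in place of 4-(dimethylamino)phenyl on a saturated chain carbon bound to an amide-type nitrogen.

For the measured compounds named here, one measured step bears on this change, and only indirectly. It is a 1.6-fold lower number from compound 2 to compound 3 (0.20 log units; within the scatter), where dimethylamino replaces phenoxy on an aromatic carbon. That exchange touches the same arm of the molecule and leaves the number within the scatter. Going by the values given here, no measured step replaces the whole aromatic ring, so this single step is a loose guide, and the range must stay wide.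

In this assay, no shift beyond the scatter is expected, and no direction is favoured. The expected step is a 1.2-fold higher number from compound 3 to compound 4 (0.08 log units; within the scatter). The estimate for compound 4 is 6000 nM, with an expected range from 2200 nM to 16000 nM.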

Compound 4, half-maximal inhibitory concentration: 7300 nM
Estimate against measurement, compound 4: 1.2-fold (0.09 log units) below, and the stated range covers the measured number.
By their numbers in this assay, from the lowest: compounds 3, 4 and 2 (each within the scatter of the next).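

In this assay, putting thiophen-2-yl in place of 4-(dimethylamino)phenyl on a saturated chain carbon bound to an amide-type nitrogen gives a 1.5-fold higher number from compound 3 to compound 4 (0.16 log units; within the scatter), so the change cannot be told apart from repeat-measurement noise. The earlier step had exchanged only a group on the aromatic ring, whereas this one replaces the whole ring: a six-membered aromatic ring of carbon only, in a group of 9 heavy atoms, gives way to a five-membered aromatic ring with 1 hetero atom, in a group of 5 heavy atoms, and the cytotoxicity number still does not move beyond the scatter. The data shown offer no measurement that could explain why this exchange leaves the number within the scatter.

All the numbers shown at this place come from aromatic groups, so it remains open whether a saturated group such as cyclohexyl, or a ring carrying a carboxylic acid or a primary amine, would shift the number beyond the scatter. Compound 1 has no number, so it adds nothing to that question.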